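Changing the aryl amide group on compound 2

This account rests on a few compounds, and the source may have more. Where it says the series, first, only, none or still open, it means among the compounds named here.

Values measured so far in a functional assay on HT-29 cells (Homo sapiens) for cytotoxicity, read by MTT assay, with a stated time of 72 h (a lower number here means a stronger inhibitor, a higher number a weaker inhibitor), are these:
- compound 1 `COc1ccc(NC(=O)CN2CCN(c3nnc(Cc4ccncc4)c4ccccc34)CC2)cc1OC` gives 40100 nM
- compound 2 `COc1ccc(NC(=O)CN2CCN(c3nnc(Cc4ccccc4)c4ccccc34)CC2)cc1OC` gives 145000 nM
- compound 3 `Cc1cccc(Cl)c1NC(=O)CN1CCN(c2nnc(Cc3ccncc3)c3ccccc23)CC1` gives 22600 nM

Compound 2 (145000 nM) has the highest number of the three. Its nearest neighbour is compound 1, and the link between them is a 3.6-fold higher number from compound 1 to compound 2 (0.56 log units; beyond the scatter) for phenyl in place of pyridin-4-yl on a saturated chain carbon bound to an aromatic carbon. That step shows where compound 2 stands, but it lies at a different place from the change considered here.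

Compound 4 `O=C(CN1CCN(c2nnc(Cc3ccccc3)c3ccccc23)CC1)Nc1cccc(Br)c1` has not yet been measured. It differs from compound 2 as follows: 3-bromophenyl in place of 3,4-dimethoxyphenyl on an amide-type nitrogen. Among the measured compounds shown here, the one measured step at this nitrogen is a 1.8-fold lower number from compound 1 to compound 3 (0.25 log units; within the scatter) and it also removes 3,4-dimethoxyphenyl. However, a different group enters there, and the parent is compound 1, not compound 2. For the measured compounds named here, no measured compound carries 3-bromophenyl, so the evidence is thin.

A small step is therefore expected, estimated as a 1.6-fold lower number from compound 2 to compound 4 (0.21 log units; within the scatter) in this case, and it may not clear the scatter. In this assay compound 4 is estimated at 90000 nM with an expected range from 35000 nM to 200000 nM for a single measurement.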

Compound 4, half-maximal inhibitory concentration: 13400 nM
Beside the measured number, compound 4's estimate is 6.7-fold (0.83 log units) above it, outside the stated range (below it).
By their numbers in this assay, from the lowest: compounds 4, 3 and 1 (each within the scatter of the next, the first and the last beyond it); then compound 2.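

In this assay, replacing 3,4-dimethoxyphenyl with 3-bromophenyl on the amide-type nitrogen gives an 11-fold lower number from compound 2 to compound 4 (1.03 log units; beyond the scatter), which shows that the aryl group at this nitrogen can strongly shift the number when phenyl is the other group on the core. Among the compounds shown here, the only earlier step at this nitrogen, a 1.8-fold lower number from compound 1 to compound 3 (0.25 log units; within the scatter), stayed within the scatter, but it brought in a different group on a parent with pyridin-4-yl, so the size of the new step could not have been read from it. The change swaps a group with hydrogen-bond acceptors for one with none and also brings in bromine, but no measurement here ties the large step to either difference or explains it.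

As far as these compounds go, it remains open whether the step comes from bromine entering or from the methoxy groups leaving, a question that a plain phenyl or a 3-methoxyphenyl on the same nitrogen could help to separate. From the compounds shown here alone, it is also open whether 3-bromophenyl would give a similar step on the parent that carries pyridin-4-yl instead of phenyl.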